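Amide Variation and Tolerance in a Cell Toxicity Assay

A few compounds are considered here, and "the series" means these few. Any claim that something is new, unique, unknown or untested is made for them only; others in the source may bear on it.

In a toxicity assay on THP-1 cells (Homo sapiens) for inhibition (a higher number here means that more compound is tolerated, a lower number that less compound is tolerated), the three measured compounds give only limits:
Compound 1 `COc1ccc(-c2cnc(NC(=O)c3ccccc3OC)n2C)cc1`: > 100000 nM
Compound 2 `COc1ccc(-c2cnc(NC(=O)c3cccc(Br)c3)n2C)cc1`: > 100000 nM
Compound 3 `CCC(=O)Nc1ncc(-c2ccc(OC)cc2)n1C`: > 100000 nM

Each of these is a limit of the assay, not a number. Compound 3 thus stands where the others stand, at the limit (the limit of > 100000 nM in this assay, at which 3 of the 3 values shown sit). The steps a step that the two limits leave unreadable from compound 1 to compound 3 and a step that the two limits leave unreadable from compound 2 to compound 3 therefore cannot be sized in this assay.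

Compound 4 `COc1ccc(-c2cnc(NC(=O)c3ccc(C#N)cc3)n2C)cc1` differs from compound 3 in one place: 4-cyanophenyl in place of ethyl on a carbonyl carbon. Within the data shown here, the measured steps offer no readable size for this kind of change, only that every value so far rests at the limit (the limit of > 100000 nM in this assay, at which 3 of the 3 values shown sit). Compound 4 is therefore expected to stay at that limit in this assay, an expected step that the limit leaves unreadable from compound 3 to compound 4. The estimate for compound 4 is 150000 nM, with a range from 70000 nM to 400000 nM.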

Compound 4, half-maximal cytotoxic concentration: > 100000 nM
Compound 4: no number, only a limit; the forecaster's own chance of this, stated with the estimate: 85%; the middle value does not contradict the limit.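

Compound 4 gives only a limit, as do compound 1, compound 2 and compound 3, so no step among them can be read in this assay: the limit of > 100000 nM in this assay, at which 4 of the 4 values shown sit.

Still open, going by these compounds, is the actual tolerated concentration of each compound, and whether changing the group on the carbonyl carbon alters it at all.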